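Swapping the aryl on the sulfur of the core

The source may hold more compounds than are shown below. What is called first, only, known or untested is meant among the compounds shown, and "the series" means these compounds.

Of the compounds shown here, three sharing one core have been tested in a functional assay on U-251 cells (Homo sapiens) for inhibition, read by sulforhodamine B assay, with a stated time of 48 h; on this read-out higher numbers stand for lower toxicity in this test and lower numbers for higher toxicity in this test. Compound 1 `CCOC(=O)[C@H](CCC(=O)O)NC(=O)c1ccc(Sc2nc3cc(N)cc(N)c3nc2-c2ccccc2)cc1` gives only a limit in this assay, < 100000 nM, so it does not yield a number to compare. Compound 2 `Nc1cc(N)c2nc(-c3ccccc3)c(Sc3ccc(F)cc3)nc2c1` gives 61700 nM in this assay, the higher of the two numbers that are known. Compound 3 `COc1cc(CNc2nc3cc(N)cc(N)c3nc2-c2ccccc2)cc(OC)c1OC` gives 30200 nM in this assay, a lower value, and the gap between compound 2 and compound 3 lies beyond the usual scatter of repeated measurements.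

Compound 4 `Nc1cc(N)c2nc(-c3ccccc3)c(Sc3ccc(Cl)c(Cl)c3)nc2c1` is still to be measured. It differs from compound 2 in one place only (3,4-dichlorophenyl in place of 4-fluorophenyl on a sulfur). Within the data shown here, no measured pair in this set shows what exchanging one aryl group on the sulfur does, so the direction of the step is an open question. Compound 3 shows that a different group at that position can move the number, but from a single comparison no trend can be drawn.

The expectation for compound 4 is a modest shift, roughly the size of the scatter or a little beyond it, toward a lower number than compound 2, with the estimated step of a 1.5-fold lower number from compound 2 to compound 4 (0.19 log units; within the scatter). Compound 4 is therefore expected to give about 40000 nM in this assay, most likely between 15000 nM and 100000 nM.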

Compound 4, concentration lethal to 50% of the cells: < 100000 nM
Compound 4 was reported as a limit; the forecaster's own chance of this, stated with the estimate: 15%; the middle value lies beyond the limit too.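

In this assay compound 4 gives < 100000 nM, which is a limit and not a number, so no step from compound 2 to compound 4 can be read: the limit of < 100000 nM in this assay, at which 2 of the 4 values shown sit.

The compounds shown leave open whether exchanging 4-fluorophenyl for 3,4-dichlorophenyl on a sulfur moves the number at all, and in which direction.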